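The source may hold more compounds than are shown below. What is called first, only, known or untested is meant among the compounds shown, and "the series" means these compounds.

Measured so far:
compound 1 `COc1ccc(NC(=O)c2nnc(COc3ccc(CCC(=O)O)cc3)s2)cc1` — > 10000 nM
compound 2 `O=C(O)CCc1ccc(OCc2nnc(C(=O)Nc3ccccc3F)s2)cc1` — 580 nM
compound 3 `O=C(O)CCc1ccc(OCc2nnc(C(=O)Nc3ccc(F)cc3)s2)cc1` — 6640 nM

All three share one core and differ only in the group carried on the amide-type nitrogen. Within the data shown here, in a functional assay on CHO cells for agonist activity at Free fatty acid receptor 1 (Homo sapiens), read by calcium flux (on this read-out higher numbers stand for an effect only at larger amounts of compound and lower numbers for an effect already at smaller amounts), compound 1 reaches only a limit of the assay, > 10000 nM; it is the one compound sitting at the limit of > 10000 nM in this assay, at which 1 of the 3 values shown sits. Compound 2 gives 580 nM and compound 3 gives 6640 nM, so the step of an 11-fold higher number from compound 2 to compound 3 (1.06 log units; beyond the scatter) is large.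

Compound 4 `Cc1ccc(NC(=O)c2nnc(COc3ccc(CCC(=O)O)cc3)s2)cc1` is not yet measured. It differs from compound 1 by methyl in place of methoxy on an aromatic carbon. Among the measured compounds shown here, the one measured step of the same kind, an at least 1.5-fold lower number from compound 1 to compound 3 (0.17 log units; that floor lies within the scatter), stayed within the scatter at its floor. A step of similar size is therefore expected, a step that the limit leaves unreadable from compound 1 to compound 4, and for compound 4 the estimate is 12000 nM, ranging from 3000 nM to 50000 nM.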

Compound 4, half-maximal effective concentration: 4300 nM
Estimate against measurement, compound 4: 2.8-fold (0.45 log units) above; the range from low to high includes it.
By their numbers in this assay, from the lowest: compound 2; then compounds 4 and 3 (each within the scatter of the next). At a limit, above all of these: compound 1.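

Methyl in place of methoxy gives an at least 2.3-fold lower number from compound 1 to compound 4 (0.36 log units; beyond the scatter), the first change at this position whose floor clears the scatter. Methyl and fluoro at this position cannot be told apart, with a 1.5-fold lower number from compound 3 to compound 4 (0.19 log units; within the scatter). Neither closes the gap to the 2-fluorophenyl group, as a 7.4-fold higher number from compound 2 to compound 4 (0.87 log units; beyond the scatter) shows.

On these data alone, compound 1 remains a limit and not a number, so the full size of its step stays open: the limit of > 10000 nM in this assay, at which 1 of the 4 values shown sits. Also open is how an amino or chloro group on this carbon would read, and whether 2-methylphenyl would match 2-fluorophenyl.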